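The source may report more compounds than this note shows. Statements on the series, on what has been measured and on what is new or still open speak of the compounds shown alone.

Measured compounds:
compound 1, `CC1CCN(c2c(S(=O)(=O)c3ccc(Cl)cc3)cnc3cc(Cl)ccc23)CC1`: 91%
compound 2, `NC(=O)C1CCN(c2c(S(=O)(=O)c3ccccc3)cnc3ccccc23)CC1`: 24.8%
compound 3, `Cc1ccc2ncc(S(=O)(=O)c3ccc(C#N)cc3)c(N3CCC(C)CC3)c2c1`: 55%

In an assay on isolated protein for displacement of a labelled ligand from metabotropic glutamate receptor 5 (Homo sapiens), with a stated time of 60 min, tested at 1 uM (on this read-out higher numbers stand for more inhibition at the one concentration tested (going by the name of the read-out) and lower numbers for less inhibition), compound 2 gives 24.8%, the lowest of the three numbers. Its nearest neighbour is compound 3 with 55%, and the widest gap separates it from compound 1 with 91%; both gaps lie beyond the usual scatter. Compound 4, `O=S(=O)(c1ccccc1)c1cnc2ccccc2c1N1CCCCCC1`, has not yet been measured. It differs from compound 2 in a single place: azepan-1-yl in place of 4-carbamoylpiperidin-1-yl on an aromatic carbon. For the measured compounds named here, no measured pair shows this exact exchange, so its effect has to be inferred. Because compound 2 sits at 24.8% while the two compounds carrying other groups at that place sit far higher, a rise is expected, estimated at a number 30.2 percentage points higher from compound 2 to compound 4 (beyond the scatter). Compound 4 is accordingly expected to give 55%, within a range from 25% to 85%.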

Compound 4, a percentage reported as inhibition, at one concentration (the size of the read-out at that concentration, not a potency): 79.9%
Compound 4: middle estimate off by 24.9 percentage points, on the low side; the range from low to high includes it.
By their numbers in this assay, from the lowest: compound 2; then compound 3; then compound 4; then compound 1.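

In this assay, putting azepan-1-yl in place of 4-carbamoylpiperidin-1-yl gives a number 55.1 percentage points higher from compound 2 to compound 4 (beyond the scatter) with the rest of the molecule unchanged. For the compounds shown here, compounds 1 and 3 differ from compound 2 in more than one place, so this is the first direct sign that the group on this aromatic carbon, ortho to the phenylsulfonyl group, can by itself change the read-out strongly. The exchange both enlarges the ring and removes the carbamoyl group, so the two changes cannot be told apart here.

Going by these compounds, an unsubstituted piperidin-1-yl group on the same core would separate them, and whether a morpholin-4-yl group at this position gives a higher or lower number also stays open. Nothing shown explains why the number rises.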